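Chloro in Place of Hydrogen, Repeated on a Second Core

The compounds below may be only part of what the source reports. "The series", "measured", "known", "first", "only" and "open" are said of these compounds alone.

Compound 1 `NS(=O)(=O)c1ccc(-n2nc(-c3ccccc3)cc2-c2cc(O)ccc2O)cc1` is the reference. In a functional assay on cells (Cancer cell lines, Homo sapiens) for cytotoxicity, read by sulforhodamine B assay, with a stated time of 48 h (on this read-out higher numbers stand for weaker inhibition of growth and lower numbers for stronger inhibition of growth), compound 1 gives 81300 nM. Compound 2 `NS(=O)(=O)c1ccc(-n2nc(-c3ccc(Cl)cc3)cc2-c2cc(O)ccc2O)cc1` carries the change chloro in place of hydrogen on an aromatic carbon and gives 14700 nM, so that a 5.5-fold lower number from compound 1 to compound 2 (0.74 log units; beyond the scatter). Compound 3 `CC(=O)NS(=O)(=O)c1ccc(-n2nc(-c3ccccc3)cc2-c2cc(O)ccc2O)cc1` differs from compound 1 by acetyl in place of hydrogen on a sulfonamide nitrogen; in this assay compound 3 gives 100000 nM, and here a 1.2-fold higher number from compound 1 to compound 3 (0.09 log units; within the scatter), so the two cores sit close together. Compound 4 `CC(=O)NS(=O)(=O)c1ccc(-n2nc(-c3ccc(Cl)cc3)cc2-c2cc(O)ccc2O)cc1` is not yet measured. It differs from compound 3 by chloro in place of hydrogen on an aromatic carbon, the same change at the same place that took compound 1 to compound 2. The step of a 5.0-fold lower number from compound 3 to compound 4 (0.70 log units; beyond the scatter) is therefore expected, resting on the earlier step of a 5.5-fold lower number from compound 1 to compound 2 (0.74 log units; beyond the scatter) and on compound 3 giving 100000 nM. For compound 4 the estimate in this assay is 20000 nM, between 8000 nM and 60000 nM.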

Compound 4, concentration for 50% growth inhibition: 44600 nM
The estimate for compound 4 lay 2.2-fold (0.35 log units) below the measured number, within the range that was stated.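

In this assay, chloro in place of hydrogen gives a 2.2-fold lower number from compound 3 to compound 4 (0.35 log units; beyond the scatter), and acetyl in place of hydrogen on the sulfonamide nitrogen gives a 3.0-fold higher number from compound 2 to compound 4 (0.48 log units; beyond the scatter). These pairs show that the chloro step kept its direction on both cores, not that it would do so on a third core, and its size cannot be told apart between them: the same change on two cores in this assay, a 5.5-fold lower number (0.74 log units; beyond the scatter) from compound 1 to compound 2 and a 2.2-fold lower number (0.35 log units; beyond the scatter) from compound 3 to compound 4, 2.5-fold (0.39 log units) apart, within the scatter of two such steps. The acetyl step lies beyond the scatter only with chloro present, yet its size also cannot be told apart between the two cores: the same change on two cores in this assay, a 1.2-fold higher number (0.09 log units; within the scatter) from compound 1 to compound 3 and a 3.0-fold higher number (0.48 log units; beyond the scatter) from compound 2 to compound 4, 2.5-fold (0.39 log units) apart, within the scatter of two such steps. On these data alone, it remains open whether fluoro, methyl or methoxy at the chloro position would follow chloro. As far as these compounds go, it also remains open whether a longer acyl chain on the sulfonamide nitrogen would follow acetyl.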